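A few compounds are considered here, and "the series" means these few. Any claim that something is new, unique, unknown or untested is made for them only; others in the source may bear on it.

Compound 1, `O=C(/C=C/c1ccc2c(c1)B(O)OC2)c1ccc(I)cc1`; compound 2, `CCc1ccc(C(=O)/C=C/c2ccc3c(c2)B(O)OC3)cc1`; compound 3, `O=C(/C=C/c1ccc2c(c1)B(O)OC2)c1ccc(O)cc1`; compound 4, `CCOC(=O)c1ccc(C(=O)/C=C/c2ccc3c(c2)B(O)OC3)cc1`, not yet measured.

In a toxicity assay on WI-38 cells (Homo sapiens) for cytotoxicity, read by MTT assay, with a stated time of 48 h (a lower number here means a stronger inhibitor, a higher number a weaker inhibitor), compound 2 gives 20600 nM. For compound 1 the read-out is a limit of the assay, > 100000 nM. For compound 3 it is likewise a limit, > 100000 nM. Compound 3 therefore stands at the weaker edge of what the assay can report; the limit of > 100000 nM in this assay, at which 2 of the 3 values shown sit, marks that edge, and only compound 2 gives a true number. The step of an at least 4.8-fold lower number from compound 1 to compound 2 (0.68 log units; beyond the scatter) and the step of an at least 4.8-fold higher number from compound 2 to compound 3 (0.68 log units; beyond the scatter) both cross the scatter, while a step that the two limits leave unreadable from compound 1 to compound 3.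

Compound 4 differs from compound 3 by ethoxycarbonyl in place of hydroxy on an aromatic carbon. Among the groups measured, only the ethyl of compound 2 gave a number; iodo in compound 1 and hydroxy in compound 3 both gave limits, so the measured steps do not point clearly in one direction for ethoxycarbonyl. Compound 4 is expected to give a number in this assay near 60000 nM, within 15000 nM to 200000 nM, which means an estimated step of an at least 1.6-fold lower number from compound 3 to compound 4 (0.22 log units; that floor lies within the scatter), with a real chance that only a limit is reported again.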

Compound 4, half-maximal inhibitory concentration: 47200 nM
Compound 4: the middle estimate sits 1.3-fold (0.10 log units) above what was measured; low and high end bracket the measured number.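

In this assay, a true number at this position, para to a large group, is no longer confined to the ethyl of compound 2, since ethoxycarbonyl also gives one, with an at least 2.1-fold lower number from compound 3 to compound 4 (0.32 log units; beyond the scatter) and an at least 2.1-fold lower number from compound 1 to compound 4 (0.32 log units; beyond the scatter). The two groups that give true numbers are not interchangeable, however, as ethoxycarbonyl in place of ethyl gives a 2.3-fold higher number from compound 2 to compound 4 (0.36 log units; beyond the scatter). Compound 1 and compound 3 remain limits rather than numbers, so the true numbers still stand beside values at the edge of what can be reported: the limit of > 100000 nM in this assay, at which 2 of the 4 values shown sit.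

Going by these compounds alone, with only two true numbers, no trend across groups at this position can be drawn. Going by these compounds, it remains open whether the ethyl end of ethoxycarbonyl matters or the carbonyl alone would do, and a carboxylic acid, a methoxycarbonyl or an amine at this position would test this further.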